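The source may report more compounds than this note shows. Statements on the series, on what has been measured and on what is new or still open speak of the compounds shown alone.

Working notes on the series in an ADME assay on PBMC cells (Homo sapiens) for cytotoxicity; a lower number here means that less compound is tolerated, a higher number that more compound is tolerated. Compound 1 `CC(CCNC(=O)c1c(Cl)cncc1Cl)N1CCC(C(Oc2ccccn2)c2ccc(Br)cc2)CC1` gives 33700 nM and compound 2 `CC(CCNC(=O)c1c(Cl)cncc1Cl)N1CCC(C(Oc2ccccn2)c2ccc(C(F)(F)F)cc2)CC1` gives 34100 nM in this assay as measured so far. Trifluoromethyl in place of bromo on an aromatic carbon makes a 1.0-fold higher number from compound 1 to compound 2 (0.01 log units; within the scatter) and so compound 1 stands level with its nearest neighbour. Compound 3 `CC(CCNC(=O)c1c(Cl)cncc1Cl)N1CCC(C(Oc2cccc(Cl)n2)c2ccc(C(F)(F)F)cc2)CC1` returns only a limit of > 32500 nM in this assay and no number. Chloro in place of hydrogen on an aromatic carbon gives a step that the limit leaves unreadable from compound 2 to compound 3 and so offers no size to work with.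

Compound 4 `CC(CCNC(=O)c1c(Cl)cncc1Cl)N1CCC(C(O)c2ccc(Br)cc2)CC1` differs from compound 1 by hydrogen in place of pyridin-2-yl on an oxygen on a saturated carbon in one place: hydrogen in place of pyridin-2-yl on an oxygen on a saturated carbon, which reads as (pyridin-2-yl)oxy to hydroxy. Neither measured step touches this place, so they bear on it only indirectly. Among the measured compounds shown here, the one readable step, a 1.0-fold higher number from compound 1 to compound 2 (0.01 log units; within the scatter) for the bromo exchange, gives no ground for expecting a large move. The expectation is therefore no change beyond the scatter, with a slight lean to a higher number, and a 1.1-fold higher number from compound 1 to compound 4 (0.05 log units; within the scatter) is the estimated step. The estimate for compound 4 is 38000 nM (expected range 18000 nM to 85000 nM).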

Compound 4, half-maximal cytotoxic concentration: 198000 nM
Compound 4: middle estimate off by 5.2-fold (0.72 log units), on the low side, and the stated range ends below it.
By their numbers in this assay, from the lowest: compounds 1 and 2 (each within the scatter of the next); then compound 4.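

In this assay, among the compounds shown here, hydrogen in place of pyridin-2-yl on an oxygen on a saturated carbon gives a 5.9-fold higher number from compound 1 to compound 4 (0.77 log units; beyond the scatter), the first readable step to lie beyond the scatter. This position therefore moves the number in a way the exchange on the aromatic carbon did not, as that exchange gives only a 1.0-fold higher number from compound 1 to compound 2 (0.01 log units; within the scatter), so the tolerated concentration in this series is shown to depend on the (pyridin-2-yl)oxy group and not only to sit level across the compounds with a number. For the compounds shown here, the single pair shows the size and direction of the step at this place, but nothing measured here accounts for it.

Still open, as far as these compounds go, is whether the higher number goes with the free hydroxy itself or simply with the loss of the pyridin-2-yl, a question that a methoxy, a phenoxy or an amine at the same place would separate. Also open, from the compounds shown here alone, is whether the same exchange gives a step of similar size on the trifluoromethyl compound 2, or on the chloro-substituted pyridin-2-yl ether of compound 3.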